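Methyl Added on a Chain Carbon at the Assay Limit

This account rests on a few compounds, and the source may have more. Where it says the series, first, only, none or still open, it means among the compounds named here.

Compound 1 `CC(C)C(NC(=O)NO)C(=O)NC1CCCCC1` gives > 100000 nM in a functional assay on MIA PaCa-2 cells (Homo sapiens) for inhibition (a lower number here means a stronger inhibitor, a higher number a weaker inhibitor), which is a limit of the assay and not a number.
Compound 2 `CCC(C)C(NC(=O)NO)C(=O)NC1CCCCC1` gives > 100000 nM in this assay, again only a limit.
Compound 3 `CC(C)C(NC(=O)n1nnc2ccccc21)C(=O)NC1CCCC1` gives > 100000 nM in this assay, also a limit.

The change from compound 1 to compound 2 is methyl in place of hydrogen on a saturated chain carbon, three bonds along the chain from an amide-type nitrogen and a carbonyl carbon. Its step, a step that the two limits leave unreadable from compound 1 to compound 2, cannot be sized because the limit of > 100000 nM in this assay, at which 3 of the 3 values shown sit, holds both ends of it. Compound 4 `CCC(C)C(NC(=O)n1nnc2ccccc21)C(=O)NC1CCCC1` carries the same change on the core of compound 3: methyl in place of hydrogen on a saturated chain carbon, three bonds along the chain from an amide-type nitrogen and a carbonyl carbon. How the core of compound 3 differs from the core of compound 1 is not broken down here.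

With every measured value sitting at the limit, the step from compound 3 to compound 4 in this assay is expected to be as unreadable as the earlier one, and the estimated step is a number no higher from compound 3 to compound 4 (the limit leaves the size open). That rests on compound 3 standing at > 100000 nM, a limit. Compound 4 is therefore expected to give about 100000 nM, most likely reported again only as a limit, within 30000 nM to 300000 nM.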

Compound 4, half-maximal inhibitory concentration: >= 100000 nM
Compound 4: a limit, no number (the forecaster's own chance of this, stated with the estimate: 85%); the middle value lies on the limit itself.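

In this assay, compound 3 and compound 4 both stand at limits and not at numbers, so no size can be read for the change from hydrogen to methyl that separates them. The compounds shown leave open whether this change alters inhibition at all where a compound gives a measurable value.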